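The source may hold more compounds than are shown below. What is called first, only, known or untested is meant among the compounds shown, and "the series" means these compounds.

In a functional assay on PC-12 cells (Rattus norvegicus) for cytotoxicity, read by MTT assay, with stated times of 2 h and 24 h, tested at 1 uM (a higher number here means a stronger effect of the compound at the concentration tested, a lower number a weaker effect), compound 3 `Oc1cc(C(F)(F)F)ccc1-c1nc(-c2ccccc2O)n(-c2ccc(OC(F)(F)F)cc2)n1` gives 65.5%. Its number sits at the bottom of the three measured, but the gaps are small: the step of a number 1.8 percentage points lower from compound 1 to compound 3 (within the scatter) from compound 1 `CC(C)(C)c1ccc(-n2nc(-c3ccc(C(F)(F)F)cc3O)nc2-c2ccccc2O)cc1`, which gives 67.3%, and the step of a number 3.5 percentage points lower from compound 2 to compound 3 (within the scatter) from compound 2 `COc1ccc(-n2nc(-c3ccc(C(F)(F)F)cc3O)nc2-c2ccccc2O)cc1`, which gives 69%, both lie within the scatter, as does a number 1.7 percentage points higher from compound 1 to compound 2 (within the scatter). Compound 4 `Oc1cc(C(F)(F)F)ccc1-c1nc(-c2ccccc2O)n(-c2ccccc2F)n1` arises from compound 3 by the change (2-fluorophenyl in place of 4-(trifluoromethoxy)phenyl on an aromatic nitrogen). Going by the values given here, no measured step exchanges the whole group on that aromatic nitrogen; the three measured steps only vary a substituent on it and were all within the scatter. Compound 4 is therefore expected to move by a number 0.5 percentage points higher from compound 3 to compound 4 (within the scatter), a step not beyond the scatter. Compound 4 is estimated at 66%, in the range 57% to 75%.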

Compound 4, a percentage reported as activity, at one concentration (the size of the read-out at that concentration, not a potency): 63.4%
Compound 4: the middle estimate sits 2.6 percentage points above what was measured, within the range that was stated.
By their numbers in this assay, from the lowest: compounds 4, 3, 1 and 2 (each within the scatter of the next).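

In this assay, exchanging the whole group on the aromatic nitrogen, rather than a substituent on it, still stays within the scatter, whichever of the three earlier compounds it is read from (a number 2.1 percentage points lower from compound 3 to compound 4 (within the scatter); a number 5.6 percentage points lower from compound 2 to compound 4 (within the scatter); a number 3.9 percentage points lower from compound 1 to compound 4 (within the scatter)). 2-Fluorophenyl, with fewer heavy atoms than 4-(trifluoromethoxy)phenyl, is thus not separated from any of the three earlier groups. Nothing available here explains this. Still open, on these data alone, is whether an amine or a carboxylic acid on that phenyl ring, or a longer alkyl chain replacing it, would step beyond the scatter.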